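The compounds below may be only part of what the source reports. "The series", "measured", "known", "first", "only" and "open" are said of these compounds alone.

In a functional assay on MCF7 cells (Homo sapiens) for cytotoxicity, read by MTT assay, with a stated time of 96 h (a lower number here means a stronger inhibitor, a higher number a weaker inhibitor), compound 1 `COc1cc(C(=O)c2cn(-c3cccc(Br)c3)cc2-c2ccccc2)cc(OC)c1OC` gives 78 nM, and compound 2 `COc1cc(C(=O)c2cn(-c3ccccc3)cc2-c2ccc(Cl)cc2)cc(OC)c1OC` gives 290 nM. Compound 2 therefore has the higher number of the two, which marks it as the weaker inhibitor, and the gap lies beyond the usual scatter. These two compounds differ in more than one place, so their values do not reveal what any single group contributes. Compound 3 `COc1cccc(-c2cn(-c3ccccc3)cc2C(=O)c2cc(OC)c(OC)c(OC)c2)c1` differs from compound 2 in one place: 3-methoxyphenyl in place of 4-chlorophenyl on an aromatic carbon. Within the data shown here, no measured pair shows the result of this exchange, so only a cautious expectation is possible. The expected change is small, a 1.3-fold lower number from compound 2 to compound 3 (0.12 log units; within the scatter), toward a slightly lower number and within the scatter. For compound 3 the estimated value is 220 nM, with an expected range from 60 nM to 800 nM.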

Compound 3, half-maximal inhibitory concentration: 180 nM
Estimate against measurement, compound 3: 1.2-fold (0.09 log units) above; the measured number falls inside the stated range.
By their numbers in this assay, from the lowest: compound 1; then compounds 3 and 2 (each within the scatter of the next).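

In this assay, putting 3-methoxyphenyl in place of 4-chlorophenyl gives a 1.6-fold lower number from compound 2 to compound 3 (0.21 log units; within the scatter), so this position, two ring bonds from the ring nitrogen, takes the exchange with no difference that can be told from the scatter. The exchange removes the chlorine and brings in a group with one more heavy atom and a hydrogen-bond acceptor, yet compound 2 and compound 3 cannot be separated by their numbers. No other measurement here helps to explain this result.

This single step cannot show whether the same holds for very different groups at this position, such as an amine or a carboxylic acid. Among these compounds, what the bromine of compound 1 contributes by itself also remains open, as no pair of compounds isolates it.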